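This account rests on a few compounds, and the source may have more. Where it says the series, first, only, none or still open, it means among the compounds named here.

Compound 1, `O=C1N=C(N2CCNCC2)CN1c1ccc(Cl)cc1`, and compound 2, `O=C1N=C(N2CCCC2)CN1c1ccc(Cl)cc1`, share one core and differ in a single group. In a physicochemical assay for lipophilicity (a lower number here means a more polar compound, a higher number a more lipophilic compound), compound 1 gives 2.3, while compound 2 gives 2. The change between them, (pyrrolidin-1-yl in place of piperazin-1-yl on a carbon with a double bond to nitrogen), made a number 0.30 log units lower from compound 1 to compound 2 (within the scatter).

Compound 3, `O=C1C=C(N2CCNCC2)C(=O)N1c1ccc(F)cc1`, is built on another core; the difference between the two cores is not broken down here. In this assay, going by the values given here, compound 3 gives 2.6, a number that lies within the scatter of the one for compound 1 and beyond the scatter from the one for compound 2.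

Compound 4, `O=C1C=C(N2CCCC2)C(=O)N1c1ccc(F)cc1`, has not yet been measured. It differs from compound 3 by pyrrolidin-1-yl in place of piperazin-1-yl on a double-bonded ring carbon. This is the same kind of change as that made from compound 1 to compound 2, though its surroundings are not identical: in the earlier pair the group sits on a carbon with a double bond to nitrogen, next to the ring nitrogen, in a five-membered non-aromatic ring with 2 nitrogen, whereas here it sits on a double-bonded ring carbon of a five-membered non-aromatic ring with 1 nitrogen. In both cases that carbon lies two ring bonds from the ring nitrogen and two ring bonds from the ring atom that bears a group of 7 heavy atoms.

Because the same kind of change gave a number 0.30 log units lower from compound 1 to compound 2 (within the scatter), a step of about the same size is expected here, a number 0.30 log units lower from compound 3 to compound 4 (within the scatter). On that basis compound 4 is estimated in this assay at 2.3, with a likely range from 1.9 to 2.7.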

Compound 4, partition coefficient: 2.3
For compound 4 middle estimate and measured number coincide at the digits printed, and the stated range covers the measured number.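

In this assay, pyrrolidin-1-yl in place of piperazin-1-yl on a double-bonded ring carbon gives a number 0.30 log units lower from compound 3 to compound 4 (within the scatter) on one core, and the same kind of change on the other core gives a number 0.30 log units lower from compound 1 to compound 2 (within the scatter) in the earlier pair, so the step printed for the first core carried over to the second at the same size. This does not show that the change has a real effect on the read-out, since each step lies within the scatter and neither can be told apart from the differences seen between repeated measurements, and two matched pairs on two cores are too few to make a rule for the whole series. Nothing shown here offers an explanation for why the two steps agree.

From the compounds shown here alone, it remains open whether the step would keep this size on a third core, or if the change were made somewhere other than on the ring carbon used here. Going by these compounds, it is also open how other amines in the same place would compare with piperazin-1-yl, such as morpholin-4-yl, piperidin-1-yl or an open-chain diethylamino group.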